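This account rests on a few compounds, and the source may have more. Where it says the series, first, only, none or still open, it means among the compounds named here.

In an assay on membranes from CHO cells for displacement of a labelled ligand from adenosine receptor A1 (Homo sapiens), read by scintillation counting, with a stated time of 60 min, tested at 1 uM (a lower number here means less inhibition, a higher number more inhibition at the concentration tested (going by the name of the read-out)), compound 1 `CC1=C(C(=O)NC(C)C)C(c2cccs2)NC(=O)N1` gives 2%, compound 2 `CC1=C(C(N)=O)C(c2ccsc2)NC(=O)N1` gives 2%, and compound 3 `CC1=C(C(=O)NC(C)C)C(c2ccsc2)NC(=O)N1` gives 8%, which is the highest of these three numbers, though both measured steps toward it, a number 6 percentage points higher from compound 1 to compound 3 (within the scatter) and a number 6 percentage points higher from compound 2 to compound 3 (within the scatter), lie within the scatter. Compound 4 `CC1=C(C(=O)OC2CCC2)C(c2ccsc2)NC(=O)N1` carries cyclobutyloxy in place of isopropylamino on a carbonyl carbon. For the measured compounds named here, only the step from compound 2 to compound 3, which altered the same amide-type position, bears on this change, and it stayed within the scatter; the conversion of the amide to an ester is not covered by any measured pair. In this assay compound 4 is therefore expected to show no step beyond the scatter, a number 3 percentage points lower from compound 3 to compound 4 (within the scatter), with an estimated value of 5% and a range from 0% to 20%.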

Compound 4, a percentage reported as inhibition, at one concentration (the size of the read-out at that concentration, not a potency): 40%
Estimate against measurement, compound 4: 35 percentage points below; measured number outside the range, above it.
By their numbers in this assay, from the lowest: compounds 1, 2 and 3 (each within the scatter of the next); then compound 4.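

In this assay, the group on the carbonyl carbon proves able to move the number, a number 32 percentage points higher from compound 3 to compound 4 (beyond the scatter) with cyclobutyloxy replacing isopropylamino, and a number 38 percentage points higher from compound 2 to compound 4 (beyond the scatter) with cyclobutyloxy replacing amino. For the compounds shown here, the earlier change from amino to isopropylamino stayed within the scatter, so these are the first steps at this position to go beyond it. Nothing available explains this rise. Cyclobutyloxy brings its oxygen and its four-membered ring together, so their shares cannot be separated. From the compounds shown here alone, whether a cyclobutylamino group or a methoxy group on the same carbonyl carbon would behave like cyclobutyloxy remains open.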